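Swapping the Phenol for a Methoxyphenyl on the Bromo Analogue

The source may report more compounds than this note shows. Statements on the series, on what has been measured and on what is new or still open speak of the compounds shown alone.

Three compounds built on one shared core were tested in a functional assay on cells (Cancer cell lines, Homo sapiens) for cytotoxicity, read by sulforhodamine B assay, with a stated time of 48 h; a lower number here means a stronger inhibitor of growth, a higher number a weaker inhibitor of growth. Compound 1 `O=C1N=C(N2N=C(c3ccccc3)CC2c2ccccc2O)S/C1=C1/C(=O)Nc2ccccc21` gives 5370 nM. Compound 2 `O=C1N=C(N2N=C(c3ccccc3)CC2c2ccccc2O)S/C1=C1/C(=O)Nc2ccc(Br)cc21`, which carries a bromo in place of a hydrogen on an aromatic carbon, gives 720 nM, and the step of a 7.5-fold lower number from compound 1 to compound 2 (0.87 log units; beyond the scatter) is a clear gain. Compound 3 `COc1ccc(C2CC(c3ccccc3)=NN2C2=NC(=O)/C(=C3\C(=O)Nc4ccccc43)S2)cc1` differs from compound 1 in another place. In this assay compound 3 gives 3450 nM. Compound 2 therefore stands as the strongest of the three, with compound 3 the nearest to it and compound 1 the furthest away, both gaps beyond the scatter.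

Compound 4 `COc1ccc(C2CC(c3ccccc3)=NN2C2=NC(=O)/C(=C3\C(=O)Nc4ccc(Br)cc43)S2)cc1` has not yet been measured. It differs from compound 2 in a single place: 4-methoxyphenyl in place of 2-hydroxyphenyl on a saturated ring carbon. The same exchange has been tried once before on this core, from compound 1 to compound 3, and the outcome there was a 1.6-fold lower number from compound 1 to compound 3 (0.19 log units; within the scatter), a shift within the scatter. Among the measured compounds shown here, that is the only measured step that bears on the question, so no change beyond the scatter is expected in this assay, with at most a small lowering of the number. The expected step is a 1.3-fold lower number from compound 2 to compound 4 (0.12 log units; within the scatter). Compound 4 is accordingly estimated at 550 nM, within a range from 250 nM to 1300 nM.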

Compound 4, concentration for total growth inhibition: 390 nM
The estimate for compound 4 lay 1.4-fold (0.15 log units) above the measured number; the range from low to high includes it.
By their numbers in this assay, from the lowest: compounds 4 and 2 (each within the scatter of the next); then compounds 3 and 1 (each within the scatter of the next).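

On the bromo core, putting 4-methoxyphenyl in place of 2-hydroxyphenyl on the saturated ring carbon again leaves this assay within the scatter, with a 1.8-fold lower number from compound 2 to compound 4 (0.27 log units; within the scatter), so this position now accepts both groups on two cores, even though the hydrogen-bond donor of 2-hydroxyphenyl is gone. A single within-scatter step could have been peculiar to one core, but this second reading closely matches the first: the same change on two cores in this assay, a 1.6-fold lower number (0.19 log units; within the scatter) from compound 1 to compound 3 and a 1.8-fold lower number (0.27 log units; within the scatter) from compound 2 to compound 4, 1.2-fold (0.07 log units) apart, within the scatter of two such steps The bromo gain also holds up on the 4-methoxyphenyl compounds, with an 8.8-fold lower number from compound 3 to compound 4 (0.95 log units; beyond the scatter), so in these four compounds the two changes behave as if each acts without regard to the other: the same change on two cores in this assay, a 7.5-fold lower number (0.87 log units; beyond the scatter) from compound 1 to compound 2 and an 8.8-fold lower number (0.95 log units; beyond the scatter) from compound 3 to compound 4, 1.2-fold (0.07 log units) apart, within the scatter of two such steps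

Going by these compounds, only these two oxygen-bearing phenyl groups appear on the saturated ring carbon, so it remains open whether a plain phenyl, an aminophenyl or a group carrying a carboxylic acid would also leave the number unchanged there. Bromo is likewise the only halogen shown on the aromatic carbon, which leaves open how chloro or fluoro in its place would compare.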